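Butyl for furan-3-yl among compounds at the limit

The compounds below may be only part of what the source reports. "The series", "measured", "known", "first", "only" and "open" are said of these compounds alone.

Three compounds sharing one core have so far given no number in a functional assay on cells (Platelet, Homo sapiens) for inhibition (on this read-out higher numbers stand for weaker inhibition and lower numbers for stronger inhibition), as a read-out. Compound 1 `CCOC(=O)c1ccc(-c2nn(Cc3ccccc3Cl)c3ccccc23)cc1` gives > 10000 nM as a limit of the assay. Compound 2 `CCOC(=O)c1ccc(-c2nn(Cc3ccccn3)c3ccccc23)cc1` gives > 10000 nM as a limit too. Compound 3 `CCOC(=O)c1ccc(-c2nn(-c3ccoc3)c3ccccc23)cc1` gives > 10000 nM as a limit as well. So compound 3 has no exact place in the series, and the limit of > 10000 nM in this assay, at which 3 of the 3 values shown sit, is the whole picture so far.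

Compound 4 `CCCCn1nc(-c2ccc(C(=O)OCC)cc2)c2ccccc21` has butyl in place of furan-3-yl on an aromatic nitrogen. The measured steps that bear on this are a step that the two limits leave unreadable from compound 1 to compound 3 and a step that the two limits leave unreadable from compound 2 to compound 3 at that same nitrogen, along with a step that the two limits leave unreadable from compound 1 to compound 2 in the group attached through a saturated chain carbon. None of them has a readable size, so they offer no direction for this change. Nothing measured therefore supports a step beyond the scatter in this assay, and the expected change is a step that the limit leaves unreadable from compound 3 to compound 4 on the estimate given here. The estimate for compound 4 is 15000 nM with an expected range of 5000 nM to 50000 nM in this measurement, and another limit is the likeliest report.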

Compound 4, half-maximal inhibitory concentration: > 10000 nM
Compound 4: no number, only a limit (the forecaster's own chance of this, stated with the estimate: 85%); the middle value does not contradict the limit.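

Compound 4 gives only a limit of the assay, as compounds 1, 2 and 3 do, and no step among these four compounds can be read because of this shared limit: the limit of > 10000 nM in this assay, at which 4 of the 4 values shown sit.

The compounds shown leave open whether any of these groups on the aromatic nitrogen gives a measurable inhibition in this assay, and how far the four compounds differ.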